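Trifluoromethoxy in Place of Methyl: Expectation for Compound 4

The compounds below may be only part of what the source reports. "The series", "measured", "known", "first", "only" and "open" are said of these compounds alone.

Compound 1 `Cc1ccc(Oc2c(/C=N/OCc3snnc3C)c(C)nn2C)cc1`: 13800 nM
Compound 2 `Cc1nnsc1CO/N=C/c1c(C)nn(C)c1Oc1ccc(OC(F)(F)F)cc1`: 12800 nM
Compound 3 `CCc1nnsc1CO/N=C/c1c(C)nn(C)c1Oc1ccc(C)cc1`: > 50000 nM

Three compounds sharing one core were tested in a functional assay on HCT-116 cells (Homo sapiens) for inhibition, read by MTT assay, with a stated time of 48 h; on this read-out lower numbers stand for stronger inhibition and higher numbers for weaker inhibition. Compound 1 gives 13800 nM and compound 2 gives 12800 nM, the two lying within the scatter of each other a 1.1-fold lower number from compound 1 to compound 2 (0.03 log units; within the scatter). For compound 3 only a limit of the assay is known, > 50000 nM, which is the limit at which one of the three values sits (the limit of > 50000 nM in this assay, at which 1 of the 3 values shown sits). On the numbers shown compound 3 therefore stands as the weakest-placed of the three, the step from compound 1 to compound 3 being an at least 3.6-fold higher number from compound 1 to compound 3 (0.55 log units; beyond the scatter).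

Compound 4 `CCc1nnsc1CO/N=C/c1c(C)nn(C)c1Oc1ccc(OC(F)(F)F)cc1` differs from compound 3 in one place: trifluoromethoxy in place of methyl on an aromatic carbon. Among the measured compounds shown here, the one measured step that bears on this change is the one from compound 1 to compound 2, which was a 1.1-fold lower number from compound 1 to compound 2 (0.03 log units; within the scatter). The same exchange on a core that already sits at the limit is expected to move the read-out in this assay no further than the scatter. Compound 4 is therefore estimated to remain at or near the limit, with the step from compound 3 to compound 4 expected to be a step that the limit leaves unreadable from compound 3 to compound 4. The estimate for compound 4 in this assay is 60000 nM, with a range from 20000 nM to 200000 nM.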

Compound 4, half-maximal inhibitory concentration: 12500 nM
Compound 4: the middle estimate sits 4.8-fold (0.68 log units) above what was measured; the measured number lies below the stated range.
By their numbers in this assay, from the lowest: compounds 4, 2 and 1 (each within the scatter of the next). At a limit, above all of these: compound 3.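

In this assay, trifluoromethoxy in place of methyl on an aromatic carbon, para to a large group, gives an at least 4.0-fold lower number from compound 3 to compound 4 (0.60 log units; beyond the scatter), so the exchange that left the read-out within the scatter on the core of compound 1 is not silent on every core: the same change on two cores in this assay, a 1.1-fold lower number (0.03 log units; within the scatter) from compound 1 to compound 2 and an at least 4.0-fold lower number (0.60 log units; beyond the scatter) from compound 3 to compound 4, at least 3.7-fold (0.56 log units) apart, beyond the scatter of two such steps The same four compounds show the other change depending on this position too, since methyl in place of hydrogen on the saturated chain carbon gives a 1.0-fold lower number from compound 2 to compound 4 (0.01 log units; within the scatter) when trifluoromethoxy is present, and the two changes therefore do not act independently here: the same change on two cores in this assay, an at least 3.6-fold higher number (0.55 log units; beyond the scatter) from compound 1 to compound 3 and a 1.0-fold lower number (0.01 log units; within the scatter) from compound 2 to compound 4, at least 3.7-fold (0.56 log units) apart, beyond the scatter of two such steps Compound 3 gives > 50000 nM, which is a limit of the assay.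

From the compounds shown here alone, what stays open is whether the same dependence appears with another group on the aromatic carbon, such as a nitrile or a chlorine, or with a longer chain such as propyl on the other side of the molecule. The four compounds also leave open whether an amine or a carboxylic acid at either place would fit this pattern in this assay.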